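The source may hold more compounds than are shown below. What is called first, only, known or untested is meant among the compounds shown, and "the series" means these compounds.

Compounds 1, 2 and 4 share one core; compound 1 `Cc1nc(-c2ccc(C(F)(F)F)cc2)sc1CNc1ccc(CCC(=O)O)cc1` and compound 2 `Cc1nc(-c2ccc(C(F)(F)F)cc2)sc1CNc1ccc(/C=C/C(=O)O)cc1` carry acids, while compound 3 `O=C(O)[C@H]1C[C@@H]1c1ccc(NCc2cccc(Oc3ccccc3)c2)cc1` has a different core and its own acid. In a functional assay on CHO cells for agonist activity at Free fatty acid receptor 1 (Homo sapiens), read by a luciferase reporter (a lower number here means a smaller maximal response, a higher number a larger maximal response), compound 1 reaches 108%, and compound 2 reaches 95%. In this assay compound 3 gives 88%; 72% (2 entries). Compound 2 stands lowest of the two single numbers shown, and the only measured step leading to it is a number 13 percentage points lower from compound 1 to compound 2 (beyond the scatter). Compound 4 `Cc1nc(-c2ccc(C(F)(F)F)cc2)sc1CNc1ccc(CCC(=O)NC(C)C)cc1` differs from compound 2 by 2-(isopropylcarbamoyl)ethyl in place of 2-carboxyethenyl on an aromatic carbon. For the measured compounds named here, that measured step concerns only the chain between the aromatic carbon and the acid; no measured step covers exchanging the carboxylic acid for an amide, and the repeat entries of compound 3, (the several entries of compound 3 in this assay, 88%; 72% (2 entries)), show only how far two readings of one compound can fall apart. The expectation for compound 4 is therefore uncertain and leans toward a smaller maximal response, with an expected step of a number 35 percentage points lower from compound 2 to compound 4 (beyond the scatter). In this assay compound 4 is expected to give 60%, between 20% and 105%.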

Compound 4, largest response reached (reported as percent of maximum), in percent of the reference or control that the assay uses: 84%
The estimate for compound 4 lay 24 percentage points below the measured number, within the range that was stated.
By their numbers in this assay, from the lowest: compound 4; then compound 2; then compound 1.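

Putting isopropylamino in place of hydroxy on the carbonyl carbon gives a number 24 percentage points lower from compound 1 to compound 4 (beyond the scatter) in this assay, so compound 4 shows that a substantial maximal response can persist with an amide at the end of this chain rather than a carboxylic acid. The exchange of 2-carboxyethenyl for 2-(isopropylcarbamoyl)ethyl gives a number 11 percentage points lower from compound 2 to compound 4 (beyond the scatter), but it changes the chain and its end group together, so this step cannot separate the two changes. Both steps are modest, and they should be read against how far repeat readings of a single compound can differ: the several entries of compound 3 in this assay, 88%; 72% (2 entries).

From the compounds shown here alone, how a primary amide, a methyl amide or a longer chain ending in a carboxylic acid would behave at this position remains open. So does the response of an isopropyl amide on the unsaturated chain of compound 2.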